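Bulky Groups and a Limit in Rat Inhibition

The source may report more compounds than this note shows. Statements on the series, on what has been measured and on what is new or still open speak of the compounds shown alone.

Measured in a functional assay for inhibition, with Rattus norvegicus as the target; a lower number here means a stronger inhibitor, a higher number a weaker inhibitor:
Compound 1 `CC(C)/N=c1\c(O)c(O)\c1=N/c1ccc(C#N)cc1`: 13700 nM
Compound 2 `CCC(C)(C)/N=c1\c(O)c(O)\c1=N/c1ccc(C#N)cc1`: > 30000 nM

Compound 2 reads > 30000 nM, which is a limit of the assay and not a number. That puts it at the limit of > 30000 nM in this assay, at which 1 of the 2 values shown sits.

Compound 3 `CC(C)(/N=c1\c(O)c(O)\c1=N/c1ccc(C#N)cc1)c1ccccc1` keeps the shared core and carries phenyl in place of ethyl on a saturated chain carbon bound to a double-bonded nitrogen and two saturated chain carbons.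

Among the compounds with values here, only one measured step bears on this, an at least 2.1-fold higher number from compound 1 to compound 2 (0.34 log units; beyond the scatter). There, ethyl in place of hydrogen at that carbon made inhibition weaker, beyond the scatter. Within the data shown here, no measurement yet compares phenyl with ethyl, so compound 3 is expected to stay a weak inhibitor in this assay, with no clear move in either direction. The expected change is a number no higher from compound 2 to compound 3 (the limit leaves the size open). For compound 3 the estimate is 30000 nM, with an expected range from 10000 nM to 90000 nM.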

Compound 3, half-maximal inhibitory concentration: > 30000 nM
Compound 3: a limit, no number; the forecaster's own chance of this, stated with the estimate: 60%; the middle value lies on the limit itself.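

In this assay, putting phenyl in place of hydrogen on this carbon gives an at least 2.1-fold higher number from compound 1 to compound 3 (0.34 log units; beyond the scatter), so a ring here, like ethyl, goes with weaker inhibition, beyond the scatter. Compound 3 reads > 30000 nM, which is a limit of the assay and not a number. The step between compound 2 and compound 3 cannot be read, and ethyl and phenyl cannot be ranked against each other: the limit of > 30000 nM in this assay, at which 2 of the 3 values shown sit.

Open, from the compounds shown here alone, is how a group of another kind on this carbon, such as an amine or a carboxylic acid, would compare with hydrogen, ethyl and phenyl. Also open, going by these compounds, is the true size of the loss of inhibition in compound 2 and compound 3; neither of them carries a number.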